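Chain to Benzyl: A Step Into Unmeasured Ground

The compounds below may be only part of what the source reports. "The series", "measured", "known", "first", "only" and "open" are said of these compounds alone.

Of the compounds shown here, two sharing one core have been measured in a functional assay on PC-3 cells (Homo sapiens) for cytotoxicity, read by MTT assay, with a stated time of 72 h; a higher number here means a weaker inhibitor, a lower number a stronger inhibitor. Compound 1 `CCCOCNc1n[n+]([O-])c2cc(OC)ccc2[n+]1[O-]` gives 10600 nM. Compound 2 `CCCCCOCNc1n[n+]([O-])c2cc(OC)ccc2[n+]1[O-]` gives 30900 nM, the higher of the two numbers, so it is the weaker of the pair. Going by the values given here, the only measured step, a 2.9-fold higher number from compound 1 to compound 2 (0.46 log units; beyond the scatter), shows that lengthening the saturated chain raised the number.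

Compound 3 `COc1ccc2c(c1)[n+]([O-])nc(NCOCc1ccccc1)[n+]2[O-]` is still to be measured in this assay. It differs from compound 2 by phenyl in place of butyl on a saturated chain carbon bound to an oxygen on a saturated carbon; seen one bond further out, pentyloxy becomes benzyloxy. Among the compounds with values here, no measured step swaps a saturated chain for an aromatic ring, so the step from compound 1 to compound 2 bears on it only loosely: it shows that the region is sensitive to what hangs off the oxygen, but not in which direction an aromatic ring will push. The step from compound 2 to compound 3 is therefore expected to be small, a 1.5-fold lower number from compound 2 to compound 3 (0.19 log units; within the scatter), with wide uncertainty. Compound 3 is estimated at 20000 nM, within a range from 6000 nM to 65000 nM.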

Compound 3, half-maximal inhibitory concentration: 88500 nM
Beside the measured number, compound 3's estimate is 4.4-fold (0.65 log units) below it; the whole stated range lies below it.
By their numbers in this assay, from the lowest: compound 1; then compound 2; then compound 3.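

The aromatic ring brings no gain at this position in this assay: replacing butyl with phenyl on the saturated chain carbon gives a 2.9-fold higher number from compound 2 to compound 3 (0.46 log units; beyond the scatter) and thus moves the number in the same direction as the earlier chain lengthening. Measured against the shorter chain of compound 1, the same region gives an 8.3-fold higher number from compound 1 to compound 3 (0.92 log units; beyond the scatter), so among these three compounds the number rises with each larger group on the oxygen, and none of the three goes against that order. Nothing available explains why benzyloxy gives a weaker result than pentyloxy, as no supporting measurement accompanies these numbers.

Going by these compounds alone, with only three groups compared, ring and size cannot be separated here: compound 3 has both a ring and more carbon atoms than compound 2, so the effect of the ring alone remains unknown. A saturated cyclohexyl ring in place of phenyl, a longer chain such as heptyl, or an amine at the end of the chain would each test a different part of this question, and the compounds shown give no answer for any of them.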